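The compounds below may be only part of what the source reports. "The series", "measured", "known", "first", "only" and "open" are said of these compounds alone.

Measured so far in an ADME assay on BJ cells (Homo sapiens) for cytotoxicity, read by CellTiter-Glo and resazurin assay, with a stated time of 72 h; on this read-out higher numbers stand for an effect only at larger amounts of compound and lower numbers for an effect already at smaller amounts:
- compound 1 `CC(C)N(Cc1cccc(OCCCCCC(=O)O)c1)C(=O)c1ccc(-c2cccc(N(C)C)c2)cc1` gives > 26000 nM, a limit of the assay.
- compound 2 `CC(C)N(Cc1cccc(OCCCCCC(=O)O)c1)C(=O)c1ccc(-c2ccoc2)cc1` gives > 26000 nM, a limit of the assay.
- compound 3 `CC(C)N(Cc1cccc(OCCCCCC(=O)O)c1)C(=O)c1ccc(-c2ccc3cc[nH]c3c2)cc1` gives > 26000 nM, a limit of the assay.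

Compound 3 thus stands at the same limit as the other two compounds in this assay; no number is known for any of them, and the limit of > 26000 nM in this assay, at which 3 of the 3 values shown sit, is all the evidence there is. The three measured steps, a step that the two limits leave unreadable from compound 1 to compound 2, a step that the two limits leave unreadable from compound 1 to compound 3 and a step that the two limits leave unreadable from compound 2 to compound 3, cannot be sized, since both ends of each sit at the limit.

Compound 4 `CC(C)N(Cc1cccc(OCCCCCC(=O)O)c1)C(=O)c1ccc(-c2cccc(Br)c2)cc1` is not yet measured. It differs from compound 3 in one place: 3-bromophenyl in place of 1H-indol-6-yl on an aromatic carbon. Among the compounds with values here, none of the measured steps can be read, so no direction or size can be drawn from them; they only show that three different groups at this position all left the effect beyond the tested range in this assay.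

On that basis the step that the limit leaves unreadable from compound 3 to compound 4 is expected to be none beyond the scatter, most likely again a limit rather than a number. For compound 4 the expected value in this assay is 40000 nM, with a range from 20000 nM to 120000 nM.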

Compound 4, half-maximal effective concentration: > 26000 nM
Compound 4 was reported as a limit (the forecaster's own chance of this, stated with the estimate: 85%); the middle value does not contradict the limit.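

In this assay compound 4 gives > 26000 nM, a limit of the assay. Its steps from compound 1, compound 2 and compound 3 cannot be read, as both ends of each sit at a limit: the limit of > 26000 nM in this assay, at which 4 of the 4 values shown sit.

The compounds shown leave open whether any group at this position gives a measurable effect, and how far these four compounds differ.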